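Swapping the imidazolidinedione for a thiazolidinedione in compound 2

The compounds below may be only part of what the source reports. "The series", "measured", "known", "first", "only" and "open" are said of these compounds alone.

Of the compounds shown here, two sharing one core have been measured in an assay on membranes from Chem-1 cells for displacement of a labelled ligand from prostaglandin E2 receptor EP3 subtype (Homo sapiens), read by scintillation counting, with a stated time of 2 h; on this read-out higher numbers stand for weaker inhibition and lower numbers for stronger inhibition. Compound 1 `CC(C)C(/C=C1\NC(=O)NC1=O)c1ccc(-c2ccc3cccc(F)c3c2)[nH]c1=O` gives 43 nM. Among the measured compounds shown here, compound 2 `CC(C)C(CC1C(=O)NC(=O)N1C)c1ccc(-c2ccc3cccc(F)c3c2)[nH]c1=O` gives 17 nM, the lowest of the two numbers, and the only measured step is a 2.5-fold lower number from compound 1 to compound 2 (0.40 log units; beyond the scatter). Compound 3 `CC(C)C(/C=C1\SC(=O)NC1=O)c1ccc(-c2ccc3cccc(F)c3c2)[nH]c1=O` is built from compound 2 by the change (a group of 8 heavy atoms (4 carbon, 1 nitrogen, 2 oxygen, 1 sulfur; one five-membered non-aromatic ring with 2 hetero atoms) in place of a group of 9 heavy atoms (5 carbon, 2 nitrogen, 2 oxygen; one five-membered non-aromatic ring with 2 hetero atoms), on a saturated chain carbon bound to an aromatic carbon and a saturated chain carbon). For the measured compounds named here, the entering group, with its 3 double bonds outside aromatic rings, resembles the group in compound 1 more than the saturated, methylated ring of compound 2, so the one measured step is read in reverse: a return toward the number of compound 1 is expected. For compound 3 the estimated step is therefore a 2.4-fold higher number from compound 2 to compound 3 (0.37 log units; beyond the scatter), upward and modest. Compound 3 is thus expected to give about 40 nM in this assay, with a plausible range from 15 nM to 110 nM.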

Compound 3, inhibition constant in the prostaglandin E2 receptor EP3 subtype assay: 13 nM
Beside the measured number, compound 3's estimate is 3.1-fold (0.49 log units) above it; measured number below the stated range.
By their numbers in the prostaglandin E2 receptor EP3 subtype assay, from the lowest: compounds 3 and 2 (each within the scatter of the next); then compound 1.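

In the prostaglandin E2 receptor EP3 subtype assay, the place on a saturated chain carbon bound to an aromatic carbon and a saturated chain carbon accepts a sulfur-containing ring without a clear shift, with a 1.3-fold lower number from compound 2 to compound 3 (0.12 log units; within the scatter). Sulfur in place of nitrogen within the unsaturated ring gives a 3.3-fold lower number from compound 1 to compound 3 (0.52 log units; beyond the scatter), so the double bonds outside the ring do not alone set the number, and the ring atom also counts. The two rings part in a physicochemical assay for solubility, measured as kinetic solubility, at pH 2 (on this read-out higher numbers stand for higher solubility and lower numbers for lower solubility), where compound 2 gives 26600 nM and compound 3 gives 4800 nM, so the sulfur-containing ring costs solubility at this place: the measured solubility of compound 2, 26600 nM, and of compound 3, 4800 nM, a 5.5-fold lower number (0.74 log units; beyond the scatter)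

Still open, from the compounds shown here alone, is whether a carboxylic acid at this place, in place of either ring, would keep the number in the prostaglandin E2 receptor EP3 subtype assay while raising it in the physicochemical assay.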